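A few compounds are considered here, and "the series" means these few. Any claim that something is new, unique, unknown or untested is made for them only; others in the source may bear on it.

Working notes on the series.

Compound 1 `CCCCN(CC)Cc1c(C(F)(F)F)nc2n(-c3c(C)cc(C)cc3C)c(Cl)cn12` carries a butyl(ethyl)amino group on the saturated chain carbon bound to the core. In an assay on cells for displacement of a labelled ligand from corticotropin-releasing factor receptor 1 (Homo sapiens), with a stated time of 100 min (a higher number here means a weaker inhibitor, a lower number a stronger inhibitor), compound 1 gives 78 nM, the highest of the three numbers recorded. Compound 2 `Cc1cc(C)c(-n2c(Cl)cn3c(CN(CCC(F)(F)F)Cc4ccccc4)c(C(F)(F)F)nc23)c(C)c1` gives 43 nM in this assay, a number that lies within the scatter of compound 1. Among the measured compounds shown here, compound 3 `Cc1cc(C)c(-n2c(Cl)cn3c(CN(CCC(F)(F)F)Cc4ccc(F)cc4)c(C(F)(F)F)nc23)c(C)c1` gives 34 nM, the only number that stands beyond the scatter from compound 1. For the measured compounds named here, the one single-point step recorded, a 1.3-fold lower number from compound 2 to compound 3 (0.10 log units; within the scatter), concerns an aromatic fluorine and says nothing about the amine.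

Compound 4 `Cc1cc(C)c(-n2c(Cl)cn3c(CN4CCCCC4)c(C(F)(F)F)nc23)c(C)c1` differs from compound 1 by piperidin-1-yl in place of butyl(ethyl)amino on a saturated chain carbon bound to an aromatic carbon. Going by the values given here, no measured pair varies the amine alone: compounds 2 and 3 change the amine and more at once, so their values show only that other tertiary amines at this position give numbers of the same order as compound 1. Among the compounds with values here, with no step that bears directly on the change, the expectation for compound 4 is a number in the same region as compound 1, and the step of a 1.3-fold higher number from compound 1 to compound 4 (0.11 log units; within the scatter) is estimated to stay within the scatter. Compound 4 is therefore expected to give about 100 nM in this assay, with a range from 35 nM to 300 nM.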

Compound 4, inhibition constant: 1200 nM
Beside the measured number, compound 4's estimate is 12-fold (1.08 log units) below it; the whole stated range lies below it.
By their numbers in this assay, from the lowest: compounds 3, 2 and 1 (each within the scatter of the next, the first and the last beyond it); then compound 4.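

In this assay, a 15-fold higher number from compound 1 to compound 4 (1.19 log units; beyond the scatter) is the first step shown that replaces butyl(ethyl)amino with piperidin-1-yl while leaving the rest of the structure unchanged, and it shows that the number is highly sensitive to the form of the amine on this saturated chain carbon bound to an aromatic carbon. The two groups have the same counts of hydrogen-bond donors and acceptors and the same net charge, so a large step arises here even though those counted features stay the same; what differs is the open chains of one group and the six-membered non-aromatic ring of the other, along with the heavy-atom count. Nothing measured here explains the size of this step.

With a single ring amine shown, it remains open whether the step follows from ring closure in general or belongs to piperidin-1-yl alone. Pyrrolidin-1-yl, azepan-1-yl or morpholin-4-yl on the same carbon, with diethylamino or dibutylamino as open-chain counterparts, would help separate ring size, ring heteroatom and chain length.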